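The source may hold more compounds than are shown below. What is called first, only, known or untested is meant among the compounds shown, and "the series" means these compounds.

Measured compounds:
- compound 1 `CC1CCN(c2c(S(=O)(=O)c3ccc(Cl)c(Cl)c3)cnc3cc(F)ccc23)CC1`: 94%
- compound 2 `CC1CCN(c2c(S(=O)(=O)c3cc(Cl)cc(Cl)c3)cnc3cc(F)ccc23)CC1`: 87%

In an assay on isolated protein for displacement of a labelled ligand from metabotropic glutamate receptor 5 (Homo sapiens), with a stated time of 60 min, tested at 1 uM (on this read-out higher numbers stand for more inhibition at the one concentration tested (going by the name of the read-out) and lower numbers for less inhibition), compound 1 gives 94% and compound 2 gives 87%. These two compounds share one core and differ only in the aryl group attached to the sulfonyl sulfur; the step of a number 7 percentage points lower from compound 1 to compound 2 (within the scatter) shows that moving one chlorine on that ring leaves the read-out essentially unchanged, so compound 2 sits alongside compound 1 rather than apart from it.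

Compound 3 `CC1CCN(c2c(S(=O)(=O)c3ccc(F)cc3)cnc3cc(F)ccc23)CC1` takes the same core and makes a further change at the same place: 4-fluorophenyl in place of 3,5-dichlorophenyl on a sulfonyl sulfur. Among the compounds with values here, the only measured step, a number 7 percentage points lower from compound 1 to compound 2 (within the scatter), concerns a rearrangement of two chlorines and does not test what happens when both chlorines leave and a single fluorine enters. Within the data shown here, no measured step therefore bears directly on this change, and the expectation for compound 3 rests on the high read-outs of both neighbours while allowing for a loss. Compound 3 is estimated to give 68% (range 35% to 95%), an expected step of a number 19 percentage points lower from compound 2 to compound 3 (beyond the scatter).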

Compound 3, a percentage reported as inhibition, at one concentration (the size of the read-out at that concentration, not a potency): 74.5%
Beside the measured number, compound 3's estimate is 6.5 percentage points below it; low and high end bracket the measured number.
By their numbers in this assay, from the lowest: compound 3; then compounds 2 and 1 (each within the scatter of the next).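

Within the data shown here, compound 3 is the first here in which both chlorines leave the ring on the sulfonyl sulfur, and this change registers in this assay as a number 12.5 percentage points lower from compound 2 to compound 3 (beyond the scatter) and as a number 19.5 percentage points lower from compound 1 to compound 3 (beyond the scatter) in the other comparison. Moving a chlorine around the ring had shown no change beyond the scatter, whereas this swap shows that the read-out does respond to what the ring carries, though compound 3 still gives 74.5% at the one concentration tested. Nothing available explains why the number falls with this swap.

Chlorine leaves and fluorine enters in the same step, so the compounds shown cannot say which of the two matters, or whether the number of substituents does. From the compounds shown here alone, how a plain phenyl, a 4-chlorophenyl or a ring carrying a methoxy group or a nitrile would read at this place remains open.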